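The source may hold more compounds than are shown below. What is called first, only, known or untested is meant among the compounds shown, and "the series" means these compounds.

Working notes on the series, oral exposure in rat.

Three analogues share one core; compound 1 `Cc1cn2c(-c3cn[nH]c3)cnc2c(Nc2cc(Cn3cccc3)ns2)n1` carries the shared core but its entry in an ADME assay on the whole organism for pharmacokinetics, with Rattus norvegicus as the target, with a stated time of 6 h, at a dose of 10 mg/kg by the oral route (a higher number here means more compound in the circulation at the dose given, a lower number less compound in the circulation), reads "not determined" (no result reported), no result having been reported. Compound 2 `Cc1ccnc(Cc2cc(Nc3nc(C)cn4c(-c5cn[nH]c5)cnc34)sn2)c1` gives 1850 ng.h/mL in this assay. Compound 3 `Cc1cccc(Cc2cc(Nc3nc(C)cn4c(-c5cn[nH]c5)cnc34)sn2)n1` gives 3100 ng.h/mL in this assay. For the measured compounds named here, of the two numbers known, compound 3 has the higher one, but the step of a 1.7-fold higher number from compound 2 to compound 3 (0.22 log units; within the scatter) stays within the scatter, so the two compounds cannot be placed in order on this assay.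

Compound 4 `Cc1cn2c(-c3cn[nH]c3)cnc2c(Nc2cc(Cc3ncccc3F)ns2)n1` is the next analogue. Relative to compound 3 the change is 3-fluoropyridin-2-yl in place of 6-methylpyridin-2-yl on a saturated chain carbon bound to an aromatic carbon. Going by the values given here, the only step that bears on it is the exchange of one methylpyridinyl group for another, a 1.7-fold higher number from compound 2 to compound 3 (0.22 log units; within the scatter), which did not move the number beyond the scatter. Among the compounds with values here, nothing more is known about this position, and no step in the set involves a fluorine. On that basis the step of a 1.2-fold lower number from compound 3 to compound 4 (0.09 log units; within the scatter) is expected to lie within the scatter, with no direction assigned. Compound 4 is therefore estimated to give 2500 ng.h/mL in this assay, with a range of 800 ng.h/mL to 7500 ng.h/mL that reflects the single, small step available as a guide.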

Compound 4, area under the concentration-time curve: 569 ng.h/mL
Beside the measured number, compound 4's estimate is 4.4-fold (0.64 log units) above it, and the stated range ends above it.
By their numbers in this assay, from the lowest: compound 4; then compounds 2 and 3 (each within the scatter of the next).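

In this assay the exchange between the two methylpyridinyl groups gave a 1.7-fold higher number from compound 2 to compound 3 (0.22 log units; within the scatter) and so did not show whether this place on a saturated chain carbon bound to an aromatic carbon matters; the 3-fluoropyridin-2-yl group shows that it does, with a 5.4-fold lower number from compound 3 to compound 4 (0.74 log units; beyond the scatter) against 6-methylpyridin-2-yl and a 3.3-fold lower number from compound 2 to compound 4 (0.51 log units; beyond the scatter) against 4-methylpyridin-2-yl on the same chain carbon. Both new steps lie beyond the scatter and point the same way, so compound 4 stands lowest of the three compounds with a number, and a change that keeps the ring type and the heavy-atom count can still move the result. No supporting measurement accompanies this drop, so the compounds shown offer no account of what lies behind it.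

The compounds shown do not separate the arrival of the fluorine from the departure of the methyl group, a question that an unsubstituted pyridin-2-yl group at this place would address. They also leave open how an amine or a carboxylic acid on the pyridine ring would fare in this assay.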